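The compounds below may be only part of what the source reports. "The series", "measured", "known", "first", "only" and "open" are said of these compounds alone.

Measured so far in a functional assay for inhibition of sodium/hydrogen exchanger (Oryctolagus cuniculus); on this read-out higher numbers stand for weaker inhibition and lower numbers for stronger inhibition:
compound 1 `Cc1cc(Sc2cccc(Cl)c2)c(S(C)(=O)=O)cc1C(=O)N=C(N)N` gives 37 nM
compound 2 `Cc1c(C(=O)N=C(N)N)ccc(Oc2cccnc2)c1S(C)(=O)=O` gives 2200 nM
compound 3 `CS(=O)(=O)c1cc(C(=O)N=C(N)N)c(N2CCCCC2)cc1N1CCCCC1` gives 1000 nM

Compound 1 holds the lowest of the three numbers. The nearest, compound 3, and the furthest, compound 2, both lie beyond the scatter above it, so compound 1 is the strongest inhibitor of the three in this assay.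

Compound 4 `Cc1cn(-c2cc(C)c(C(=O)N=C(N)N)cc2S(C)(=O)=O)cn1` has not yet been measured. It differs from compound 1 in one place: 4-methyl-1H-imidazol-1-yl in place of (3-chlorophenyl)sulfanyl on an aromatic carbon. Going by the values given here, no step between two measured compounds covers this change. Because compound 2 gives 2200 nM and compound 3 gives 1000 nM, the other patterns seen here sit far above compound 1, and a loss is expected, estimated as an 8.1-fold higher number from compound 1 to compound 4 (0.91 log units; beyond the scatter). Compound 4 is therefore estimated at 300 nM, with a range from 60 nM to 2000 nM.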

Compound 4, half-maximal inhibitory concentration: 28 nM
For compound 4 the middle estimate is 11-fold (1.03 log units) above the measured one, and the stated range ends above it.
By their numbers in this assay, from the lowest: compounds 4 and 1 (each within the scatter of the next); then compound 3; then compound 2.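

In this assay, 4-methyl-1H-imidazol-1-yl in place of (3-chlorophenyl)sulfanyl gives a 1.3-fold lower number from compound 1 to compound 4 (0.12 log units; within the scatter) and thus no difference that can be told apart. Going by these compounds alone, this is the first single-place comparison at this aromatic carbon, ortho to a methylsulfonyl group, and it shows that a five-membered aromatic ring with 2 hetero atoms and a group holding a six-membered aromatic ring of carbon only can stand there with like values. Nothing measured here explains this match.

As far as these compounds go, whether the 4-methyl group on the entering ring matters remains open. So does whether a carboxylic acid or a primary amine would be matched at this position.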